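The compounds below may be only part of what the source reports. "The series", "measured", "known", "first", "only" and "open" are said of these compounds alone.

Compound 1 `O=C(Nc1cccc(-n2cc(-c3ccncc3)c(-c3ccc(Cl)c(O)c3)n2)c1)Nc1cccc(C(F)(F)F)c1` gives > 32500 nM in a functional assay on 786-0 cells (Homo sapiens) for inhibition, read by sulforhodamine B assay, with a stated time of 48 h (a higher number here means that more compound is tolerated, a lower number that less compound is tolerated), a limit of the assay rather than a measured number.
Compound 2 `COc1cc(-c2nn(-c3cccc(NC(=O)Nc4ccc(Cl)c(Cl)c4)c3)cc2-c2ccncc2)ccc1Cl` gives > 50000 nM in this assay, again a limit and not a number.

Compound 2 therefore stands where the assay stops reporting: both values shown are limits, and nothing on these numbers sets compound 2 apart from compound 1. Compound 3 `O=C(Nc1cccc(-n2cc(-c3ccncc3)c(-c3ccc(Cl)c(O)c3)n2)c1)Nc1ccc(Cl)c(Cl)c1` has not yet been measured. It differs from compound 2 in one place: hydrogen in place of methyl on an oxygen on an aromatic ring. Compound 1 already carries that same hydroxy group on its ring and also reaches only a limit, as the limit of > 32500 nM in this assay, at which 1 of the 2 values shown sits, shows. For the change from compound 2 to compound 3 no step beyond the scatter is expected in this assay, in either direction, so compound 3 is expected to end at a limit as well. The estimate for compound 3 is 50000 nM, within 20000 nM to 120000 nM. The expected step is a number no higher from compound 2 to compound 3 (the limit leaves the size open), essentially none.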

Compound 3, concentration lethal to 50% of the cells: > 32500 nM
Compound 3 gave a limit, no number; the forecaster's own chance of this, stated with the estimate: 80%; the middle value lies beyond the limit too.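

Compound 3, like compound 1 and compound 2, ends at a limit rather than a number, so no step can be read from compound 2 to compound 3 or from compound 1 to compound 3. The compounds shown leave open whether methoxy or hydroxy, or 3,4-dichlorophenyl or 3-(trifluoromethyl)phenyl, makes any difference in this assay.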